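A few compounds are considered here, and "the series" means these few. Any claim that something is new, unique, unknown or untested is made for them only; others in the source may bear on it.

Measured so far:
Compound 1 `COc1cccc(NC(=O)c2nnn(Cc3cc(C)on3)c2N)c1` — in a toxicity assay on Vero cells (Chlorocebus sabaeus) for inhibition (a lower number here means that less compound is needed, a higher number that more compound is needed for the effect), compound 1 gives > 50100 nM, which is a limit of the assay rather than a number.
Compound 2 `COc1cccc(NC(=O)c2nnn(CC3CCNCC3)c2N)c1` — in this assay compound 2 gives > 50100 nM, again a limit.
Compound 3 `COc1cccc(NC(=O)c2nnn(Cc3ccccc3)c2N)c1` — in this assay compound 3 gives > 50100 nM, again a limit.

Compound 2 thus stands at the limit, as do all values here (the limit of > 50100 nM in this assay, at which 3 of the 3 values shown sit). Compound 4 `COc1cccc(NC(=O)c2nnn(CC3CCN(C(=O)OC(C)(C)C)CC3)c2N)c1` differs from compound 2 by tert-butoxycarbonyl in place of hydrogen on an amine nitrogen in a ring. Within the data shown here, no measured step shares this change, and the steps that exist, a step that the two limits leave unreadable from compound 1 to compound 2, a step that the two limits leave unreadable from compound 1 to compound 3 and a step that the two limits leave unreadable from compound 2 to compound 3, are all unreadable in size; both ends of each sit at the limit (the limit of > 50100 nM in this assay, at which 3 of the 3 values shown sit). No step beyond the scatter is therefore expected. Compound 4 is expected to remain at the limit, with an estimated value of 50100 nM, between 20000 nM and 200000 nM. This corresponds to an expected step of a number no higher from compound 2 to compound 4 (the limit leaves the size open).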

Compound 4, half-maximal effective concentration: > 50100 nM
Compound 4: only a limit was reported; the forecaster's own chance of this, stated with the estimate: 85%; the middle value lies on the limit itself.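

Compound 2 and compound 4 both sit at a limit rather than at a number, so no step between them can be read: the limit of > 50100 nM in this assay, at which 4 of the 4 values shown sit.

The compounds shown leave open whether any of these groups changes the concentration needed for the effect in this assay.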